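Cyclopropyl on the piperazine of compound 1

The source may report more compounds than this note shows. Statements on the series, on what has been measured and on what is new or still open speak of the compounds shown alone.

Among the measured compounds shown here, in an ADME assay on microsomes from liver (Homo sapiens) for metabolic stability, read by LC-MS, with a stated time of 10 min, tested at 0.5 uM (on this read-out higher numbers stand for a more stable compound and lower numbers for a less stable compound), compound 1 `c1ccc2c(c1)CN[C@@H](CN(CCCN1CCNCC1)[C@H]1CCCc3cccnc31)C2` gives 100% and stands highest of the two numbers so far. The other number belongs to compound 2 `c1cnc2c(c1)CN[C@@H](CN(CCCN1CCNCC1)[C@H]1CCCc3cccnc31)C2` at 79% in the same read-out. The next structure is compound 3 `c1ccc2c(c1)CN[C@@H](CN(CCCN1CCN(C3CC3)CC1)[C@H]1CCCc3cccnc31)C2`, which carries cyclopropyl in place of hydrogen on an amine nitrogen in a ring turns piperazin-1-yl into 4-cyclopropylpiperazin-1-yl.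

For the measured compounds named here, only one measured step exists, a number 21 percentage points lower from compound 1 to compound 2 (beyond the scatter) in this series. That modest step changes a different group, on a saturated chain carbon bound to an amine nitrogen, so it serves only as a gauge of size. Going by the values given here, no measured step touches the piperazine nitrogen. With compound 1 at 100% there is no room for a higher number, so a drop is expected, of similar size or smaller, though a change within the scatter remains possible. The expected move is a number 15 percentage points lower from compound 1 to compound 3 (beyond the scatter) in this assay as an uncertain estimate. For compound 3 the estimate is 85% with an expected range from 65% to 100% for the coming measurement.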

Compound 3, percent of the compound remaining: 21%
Beside the measured number, compound 3's estimate is 64 percentage points above it; measured number outside the range, below it.
By their numbers in this assay, from the lowest: compound 3; then compound 2; then compound 1.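

In this assay the amine nitrogen in the ring of the piperazin-1-yl group proves to be a highly sensitive place, since cyclopropyl in place of hydrogen there gives a number 79 percentage points lower from compound 1 to compound 3 (beyond the scatter) in a single change. Among the compounds shown here, the only earlier step, a number 21 percentage points lower from compound 1 to compound 2 (beyond the scatter) at a different place in the molecule, was modest, whereas this one is large, so the entering cyclopropyl, with no hydrogen-bond donors or acceptors and no net charge, moves the read-out much further than the earlier exchange did. Nothing measured here accounts for the size of this step.

The compounds shown cannot separate an effect specific to cyclopropyl from one shared by other groups on this nitrogen, so methyl, isopropyl or acetyl at the same place would show whether the low number follows any carbon substituent or this three-membered ring alone. As far as these compounds go, it also remains open whether 4-cyclopropylpiperazin-1-yl would lower the number to a similar degree on the core of compound 2, where the earlier step already stands.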